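The compounds below may be only part of what the source reports. "The series", "measured", "known", "first", "only" and "open" are said of these compounds alone.

Compound 1 `Cn1ccc2c(Oc3ccc(NC(=O)c4nn(-c5ccc(Cl)cc5)ccc4=O)cc3F)ccnc21` gives > 60000 nM in a functional assay on PC-3 cells (Homo sapiens) for cytotoxicity, read by MTT assay, with a stated time of 72 h (a higher number here means a weaker inhibitor, a lower number a stronger inhibitor), a limit of the assay.
Compound 2 `Cn1ccc2c(Oc3ccc(NC(=O)c4nn(-c5ccc(Cl)c(F)c5)ccc4=O)cc3F)ccnc21` gives 17900 nM in this assay.
Compound 3 `Cc1cc(=O)n(-c2ccc(F)cc2)nc1C(=O)Nc1ccc(Oc2ncnc3[nH]ccc23)cc1` gives > 60000 nM in this assay, a limit of the assay.

The change from compound 1 to compound 2 is fluoro in place of hydrogen on an aromatic carbon, and it made an at least 3.3-fold lower number from compound 1 to compound 2 (0.52 log units; beyond the scatter). Compound 4 `Cc1cc(=O)n(-c2ccc(F)cc2)nc1C(=O)Nc1ccc(Oc2ncnc3[nH]ccc23)c(F)c1` carries the same kind of change relative to compound 3, namely (fluoro in place of hydrogen on an aromatic carbon); the surroundings differ, since in compound 2 the fluoro sits ortho to a chloro group, while in compound 4 it sits ortho to a large group. The difference between the core of compound 1 and the core of compound 3 is not broken down here. Compound 3 sits at the limit of > 60000 nM in this assay, at which 2 of the 3 values shown sit, so the size of any gain is uncertain. By analogy with compound 2, the step from compound 3 to compound 4 in this assay is expected to be an at least 1.5-fold lower number from compound 3 to compound 4 (0.17 log units; that floor lies within the scatter). Compound 4 is therefore estimated at 40000 nM, between 12000 nM and 150000 nM.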

Compound 4, half-maximal inhibitory concentration: 17300 nM
For compound 4 the middle estimate is 2.3-fold (0.36 log units) above the measured one; the measured number falls inside the stated range.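

In this assay, fluoro in place of hydrogen on an aromatic carbon gives an at least 3.4-fold lower number from compound 3 to compound 4 (0.54 log units; beyond the scatter), so the direction of the change carries over to a second core: the same change on two cores in this assay, an at least 3.3-fold lower number (0.52 log units; beyond the scatter) from compound 1 to compound 2 and an at least 3.4-fold lower number (0.54 log units; beyond the scatter) from compound 3 to compound 4; the limit leaves it open whether they differ

The true sizes of the two steps stay unknown, since compound 1 and compound 3 both stand at a limit of the assay rather than at a number: the limit of > 60000 nM in this assay, at which 2 of the 4 values shown sit.

Two pairs in one cell assay show a shared direction on these two cores, but they do not show that it would hold on any other core.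

From the compounds shown here alone, it remains open whether a methoxy group or a nitrile in the same place would also lower the number. Going by these compounds, it also remains open how far the number would fall with a second fluoro on the same ring.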